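This account rests on a few compounds, and the source may have more. Where it says the series, first, only, none or still open, it means among the compounds named here.

Compounds measured so far:
compound 1, `O=C(Nc1ccc2[nH]ccc2n1)[C@H]1CCCN1C(=O)C1(c2cccc(Cl)c2)CCCC1`, 0.159 nM
compound 2, `O=C(Nc1ccc2[nH]ncc2n1)[C@H]1CCCN1C(=O)C1(c2cccc(Cl)c2)CCCC1`, 0.159 nM
compound 3, `O=C(Nc1ccc2[nH]c(=O)[nH]c2c1)[C@H]1CCCN1C(=O)C1(c2cccc(Cl)c2)CCCC1`, 0.398 nM

In an assay on isolated protein for inhibition of histone acetyltransferase p300 (Homo sapiens), with a stated time of 60 min (a higher number here means a weaker inhibitor, a lower number a stronger inhibitor), compound 3 stands with the highest number of the three. Its nearest neighbour is compound 1, as the step of a 2.5-fold higher number from compound 1 to compound 3 (0.40 log units; beyond the scatter) shows; the step of a 2.5-fold higher number from compound 2 to compound 3 (0.40 log units; beyond the scatter) is of the same size, so compound 3 is set apart from both by a modest margin, while compound 1 and compound 2 lie within the scatter of each other, no change at the digits printed from compound 1 to compound 2 (within the scatter).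

Compound 4, `O=C1Cc2cc(NC(=O)[C@H]3CCCN3C(=O)C3(c4cccc(Cl)c4)CCCC3)ccc2N1`, keeps the shared core of compound 3 and differs only in the group on the amide-type nitrogen: a group of 10 heavy atoms (8 carbon, 1 nitrogen, 1 oxygen; one five-membered non-aromatic ring with 1 hetero atom, one six-membered aromatic ring of carbon only) in place of a group of 10 heavy atoms (7 carbon, 2 nitrogen, 1 oxygen; one five-membered aromatic ring with 2 hetero atoms, one six-membered aromatic ring of carbon only), on an amide-type nitrogen. Within the data shown here, two measured steps bear on such a change of this group, a 2.5-fold higher number from compound 1 to compound 3 (0.40 log units; beyond the scatter) and a 2.5-fold higher number from compound 2 to compound 3 (0.40 log units; beyond the scatter), and both were modest; the third, no change at the digits printed from compound 1 to compound 2 (within the scatter), gave nothing beyond the scatter. All three variations of this group thus stayed within a narrow band, and the replacement in compound 4 is expected to do the same, with a step of a 1.1-fold higher number from compound 3 to compound 4 (0.05 log units; within the scatter) in this assay that need not exceed the scatter in either direction. Compound 4 is therefore estimated at 0.45 nM in this assay, with a range from 0.15 nM to 1.3 nM.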

Compound 4, half-maximal inhibitory concentration: 0.794 nM
For compound 4 the middle estimate is 1.8-fold (0.25 log units) below the measured one; the range from low to high includes it.
By their numbers in this assay, from the lowest: compounds 1 and 2 (each within the scatter of the next); then compounds 3 and 4 (each within the scatter of the next).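

In this assay, the group with a five-membered non-aromatic ring and 1 hydrogen-bond donor takes the place of the one with a five-membered aromatic ring and 2 hydrogen-bond donors, and the result is a 2.0-fold higher number from compound 3 to compound 4 (0.30 log units; within the scatter), so this exchange on the amide-type nitrogen does not separate the two compounds. Set against the two groups with a six-membered aromatic ring with 1 hetero atom, the same group gives a 5.0-fold higher number from compound 1 to compound 4 (0.70 log units; beyond the scatter) and a 5.0-fold higher number from compound 2 to compound 4 (0.70 log units; beyond the scatter), the widest steps seen at this position so far, though still modest ones, and the four compounds now fall into two pairs, with compounds 1 and 2 at the lower numbers and compounds 3 and 4 at the higher. No measurement at hand accounts for either the small step or the larger ones.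

Every group shown here at this position combines a five-membered ring with a six-membered aromatic ring, so it remains open how a single ring such as plain phenyl, or a group bearing an amine or a carboxylic acid, would behave in this assay. As far as these compounds go, whether these steps would hold with a different shared core also remains open.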